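A few compounds are considered here, and "the series" means these few. Any claim that something is new, unique, unknown or untested is made for them only; others in the source may bear on it.

In an ADME assay on HEK293 cells (Homo sapiens) for cytotoxicity, read by MTT assay, with a stated time of 72 h (on this read-out higher numbers stand for weaker inhibition and lower numbers for stronger inhibition), compound 1 `O=C(CN1CCN(C(=O)c2ccc(Cl)cc2)CC1)N1CCN(CCCc2c[nH]c3ccccc23)CC1` gives 98200 nM. Compound 2 `COc1ccc(C(=O)N2CCN(CC(=O)N3CCN(CCCc4c[nH]c5ccccc45)CC3)CC2)cc1` differs from it by methoxy in place of chloro on an aromatic carbon, and in this assay compound 2 gives 156000 nM, a step of a 1.6-fold higher number from compound 1 to compound 2 (0.20 log units; within the scatter). Compound 3 `COc1ccc2[nH]cc(CCCN3CCN(C(=O)CN4CCN(C(=O)c5ccc(Cl)cc5)CC4)CC3)c2c1` rests on a different core, set apart from compound 1 by methoxy in place of hydrogen on an aromatic carbon; in this assay compound 3 gives 117000 nM, so a 1.2-fold higher number from compound 1 to compound 3 (0.08 log units; within the scatter). Compound 4 `COc1ccc(C(=O)N2CCN(CC(=O)N3CCN(CCCc4c[nH]c5ccc(OC)cc45)CC3)CC2)cc1` has not been measured; it differs from compound 3 by methoxy in place of chloro on an aromatic carbon, the same change that separates compound 2 from compound 1, at a place described in identical words. The step is expected to be a 1.5-fold higher number from compound 3 to compound 4 (0.19 log units; within the scatter), close to the earlier one, because a 1.6-fold higher number from compound 1 to compound 2 (0.20 log units; within the scatter) stayed within the scatter. Compound 4 is therefore estimated at 180000 nM, expected to fall between 90000 nM and 360000 nM.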

Compound 4, half-maximal inhibitory concentration: 190000 nM
The estimate for compound 4 lay 1.1-fold (0.02 log units) below the measured number; the measured number falls inside the stated range.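

In this assay, methoxy in place of chloro gives a 1.6-fold higher number from compound 3 to compound 4 (0.21 log units; within the scatter), and this step matches the one seen on the other core: the same change on two cores in this assay, a 1.6-fold higher number (0.20 log units; within the scatter) from compound 1 to compound 2 and a 1.6-fold higher number (0.21 log units; within the scatter) from compound 3 to compound 4, 1.0-fold (0.01 log units) apart, within the scatter of two such steps. Methoxy in place of hydrogen on an aromatic carbon gives a 1.2-fold higher number from compound 2 to compound 4 (0.09 log units; within the scatter), and it also matches its earlier counterpart: the same change on two cores in this assay, a 1.2-fold higher number (0.08 log units; within the scatter) from compound 1 to compound 3 and a 1.2-fold higher number (0.09 log units; within the scatter) from compound 2 to compound 4, 1.0-fold (0.01 log units) apart, within the scatter of two such steps. For the compounds shown here, all of these steps lie within the scatter, so the agreement shows only that neither change produced a measurable step on either core; it does not show that a larger effect would carry from one core to another.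

The compounds shown leave open whether an amine or a carboxylic acid in place of the chloro would give a step beyond the scatter. They also leave open whether such a step would repeat on both cores.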